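Removing One Chloro from Compound 3

The source may hold more compounds than are shown below. What is called first, only, known or untested is meant among the compounds shown, and "the series" means these compounds.

- Compound 1 `O=C(NO)c1ccc(NCc2nc(-c3cccc(Cl)c3)nn2-c2ccccc2)cc1`: 5760 nM
- Compound 2 `COc1ccc(-n2nc(-c3ccc(O)cc3)nc2CNc2ccc(C(=O)NO)cc2)cc1`: > 20000 nM (a limit, not a number)
- Compound 3 `O=C(NO)c1ccc(NCc2nc(-c3ccccc3)nn2-c2cccc(Cl)c2)cc1`: 13700 nM

In a functional assay on MGC-803 cells (Homo sapiens) for antiproliferative activity, read by MTT assay, with a stated time of 72 h (on this read-out higher numbers stand for weaker inhibition and lower numbers for stronger inhibition), compound 3 gives 13700 nM, the higher of the two actual numbers. Compound 1 gives 5760 nM, a lower number and a gap beyond the usual scatter. Compound 2 reports only a limit, > 20000 nM.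

Compound 4 `O=C(NO)c1ccc(NCc2nc(-c3ccccc3)nn2-c2ccccc2)cc1` has hydrogen in place of chloro on an aromatic carbon, turning 3-chlorophenyl into phenyl: hydrogen in place of chloro on an aromatic carbon. Going by the values given here, no measured pair shows this change alone. In this assay, the expected change, a 1.1-fold lower number from compound 3 to compound 4 (0.06 log units; within the scatter), is estimated to stay within the scatter, with no clear direction. For compound 4, the estimated value is 12000 nM, with an expected range of 5000 nM to 20000 nM.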

Compound 4, half-maximal inhibitory concentration: 17700 nM
Compound 4: the middle estimate sits 1.5-fold (0.17 log units) below what was measured; the measured number falls inside the stated range.
By their numbers in this assay, from the lowest: compound 1; then compounds 3 and 4 (each within the scatter of the next). At a limit, above all of these: compound 2.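

In this assay, replacing chloro with hydrogen at this position gives a 1.3-fold higher number from compound 3 to compound 4 (0.11 log units; within the scatter), so chloro here has no clear effect on the number. The same replacement on the other phenyl gives a 3.1-fold higher number from compound 1 to compound 4 (0.49 log units; beyond the scatter), so only at that position does the swap move the number beyond the scatter. Nothing measured here explains this contrast. From the compounds shown here alone, it remains open whether a larger change at this position, such as an amine or a carboxylic acid in place of chloro, would shift the number.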